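A few compounds are considered here, and "the series" means these few. Any claim that something is new, unique, unknown or untested is made for them only; others in the source may bear on it.

In a functional assay on MCF7 cells (Homo sapiens) for cytotoxicity, read by CellTiter-Glo, with a stated time of 5 days (on this read-out higher numbers stand for weaker inhibition and lower numbers for stronger inhibition), three compounds on a shared core have been measured: compound 1 (`CC/C(=C(/c1ccc(/C=C/C(=O)O)cc1)c1ccc2[nH]ncc2c1)c1ccccc1Cl`) gives 2 nM and compound 2 (`CC/C(=C(/c1ccc(/C=C/C(=O)O)cc1)c1ccc2[nH]ncc2c1)c1ccccc1OC`) gives 25 nM while compound 3 (`CC/C(=C(/c1ccc(/C=C/C(=O)O)cc1)c1ccc2[nH]ncc2c1)c1ccc(C#N)cc1Cl`) gives 4 nM in the same test. Compound 3 thus stands level with compound 1 (a 2.0-fold higher number from compound 1 to compound 3 (0.30 log units; within the scatter)) and well on the stronger side of compound 2 (a 6.3-fold lower number from compound 2 to compound 3 (0.80 log units; beyond the scatter)).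

Compound 4 (`CC/C(=C(/c1ccc(/C=C/C(=O)O)cc1)c1ccc2[nH]ncc2c1)c1cnccc1C`) keeps the shared core and carries 4-methylpyridin-3-yl in place of 2-chloro-4-cyanophenyl on a double-bonded chain carbon bound to a double-bonded chain carbon and a saturated chain carbon. Going by the values given here, no measured step brings in a 4-methylpyridin-3-yl group, so the evidence is indirect. The nearest guide is the large step that came with methoxy in place of chloro (a 13-fold higher number from compound 1 to compound 2 (1.10 log units; beyond the scatter)). Compound 4 also lacks the chloro group, and among the measured compounds only compound 2 (at 25 nM) does too. What is expected in this assay is therefore a modest step towards weaker inhibition (a 4.0-fold higher number from compound 3 to compound 4 (0.60 log units; beyond the scatter)), though one within the scatter cannot be excluded. In size it would be close to the measured step in the opposite direction (a 6.3-fold lower number from compound 2 to compound 3 (0.80 log units; beyond the scatter)). Compound 4 is estimated at 16 nM (expected range 4 nM to 60 nM).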

Compound 4, half-maximal inhibitory concentration: 150 nM
Estimate against measurement, compound 4: 9.4-fold (0.97 log units) below; the whole stated range lies below it.
By their numbers in this assay, from the lowest: compounds 1 and 3 (each within the scatter of the next); then compound 2; then compound 4.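

In this assay, 4-methylpyridin-3-yl on this double-bonded chain carbon brings the largest losses seen so far in the series, with a 38-fold higher number from compound 3 to compound 4 (1.57 log units; beyond the scatter) and a 75-fold higher number from compound 1 to compound 4 (1.88 log units; beyond the scatter), so this position tolerates chloro-bearing phenyl groups far better than this group. The chloro group's absence does not set the level by itself, as compound 2 also lacks chloro and the change to 4-methylpyridin-3-yl still gives a 6.0-fold higher number from compound 2 to compound 4 (0.78 log units; beyond the scatter), a step that shows that a chloro-free group at this place can lose further ground. Nothing measured on these compounds explains why this replacement costs so much.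

The compounds shown do not separate the contribution of the ring nitrogen from that of the methyl group, and a phenyl ring carrying methyl or a pyridine ring carrying chloro would be needed to pull the two apart. From the compounds shown here alone, it also remains open whether a pyridine ring at this place could regain strength with a nitrile or an amine on it, and whether the same ranking would hold in a test other than this one.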